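Thiophene for thiazole on the anilide of compound 1

The source may hold more compounds than are shown below. What is called first, only, known or untested is meant among the compounds shown, and "the series" means these compounds.

Compound 1 `O=C(Nc1ccc(-c2cscn2)cc1)C1CCCN(Cc2ccc(F)c(F)c2)C1` gives 880 nM in a functional assay on A-375 cells (Homo sapiens) for antiproliferative activity (a lower number here means a stronger inhibitor, a higher number a weaker inhibitor), the lowest of the numbers shown. Compound 2 `O=C(Nc1ccc(-c2cscn2)cc1)C1CCCN(Cc2ccccc2F)C1` gives 4000 nM, and the step of a 4.5-fold higher number from compound 1 to compound 2 (0.66 log units; beyond the scatter). Compound 3 `O=C(Nc1ccc(-c2cscn2)cc1)C1CCCN(Cc2cccnc2)C1` gives the limit > 20000 nM, a limit of the assay (the limit of > 20000 nM in this assay, at which 1 of the 3 values shown sits). The step of an at least 22-fold higher number from compound 1 to compound 3 (1.35 log units; beyond the scatter), and the step of an at least 5.0-fold higher number from compound 2 to compound 3 (0.69 log units; beyond the scatter). Compound 4 `O=C(Nc1ccc(-c2cccs2)cc1)C1CCCN(Cc2ccc(F)c(F)c2)C1` carries thiophen-2-yl in place of 1,3-thiazol-4-yl on an aromatic carbon. For the measured compounds named here, every measured step changes the group on the saturated chain carbon bound to the amine nitrogen in the ring; none touches the aromatic carbon para to the large group, so no measured step bears on this change. The expected step of a 1.4-fold higher number from compound 1 to compound 4 (0.13 log units; within the scatter) is therefore taken to stay within the scatter. Compound 4 is estimated at 1200 nM, between 400 nM and 4000 nM.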

Compound 4, half-maximal inhibitory concentration: 390 nM
Compound 4: the middle estimate sits 3.1-fold (0.49 log units) above what was measured; the measured number lies below the stated range.
By their numbers in this assay, from the lowest: compound 4; then compound 1; then compound 2. At a limit, above all of these: compound 3.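

Thiophen-2-yl in place of 1,3-thiazol-4-yl on an aromatic carbon para to a large group gives a 2.3-fold lower number from compound 1 to compound 4 (0.35 log units; beyond the scatter), so activity in this assay also responds to this position and not only to the group on the ring amine nitrogen. The ring nitrogen of the 1,3-thiazol-4-yl is therefore not required for activity in this pair. Nothing shown accounts for the step.

Going by these compounds, whether thiophen-2-yl gives a similar step alongside the 2-fluorophenyl or pyridin-3-yl groups remains open. So does the outcome of a furan-2-yl or plain phenyl ring at this aromatic carbon.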